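The source may report more compounds than this note shows. Statements on the series, on what has been measured and on what is new or still open speak of the compounds shown alone.

Measured compounds:
- compound 1 `Nc1scc(CN2CCN(c3cc(Cl)cc(Cl)c3)CC2)c1C(=O)c1ccc(Cl)cc1`, giving 1% in an assay on CHO cells for displacement of a labelled ligand from adenosine receptor A1 (Homo sapiens), read by scintillation counting, with a stated time of 120 min, tested at 10 uM; on this read-out higher numbers stand for more inhibition at the one concentration tested (going by the name of the read-out) and lower numbers for less inhibition
- compound 2 `Nc1scc(CN2CCN(c3cccc(C(F)(F)F)c3)CC2)c1C(=O)c1ccc(Cl)cc1`, giving 0% in this assay

Compound 2 sits at the bottom of these two numbers, but the gap between them is a number 1 percentage points lower from compound 1 to compound 2 (within the scatter), so the two are indistinguishable here and neither can be called the weaker. Compound 3 `Nc1scc(CN2CCN(c3cccnc3)CC2)c1C(=O)c1ccc(Cl)cc1` arises from compound 2 by one change: pyridin-3-yl in place of 3-(trifluoromethyl)phenyl on an amine nitrogen in a ring. For the measured compounds named here, the only measured step that bears on this is the earlier swap of the group on the same ring nitrogen, which gave a number 1 percentage points lower from compound 1 to compound 2 (within the scatter). With both known compounds near zero and that step inside the scatter, no step beyond the scatter is expected for this change either. For compound 3 an inhibition of 2% is expected, within a range of 0% to 10%. The expected step is therefore a number 2 percentage points higher from compound 2 to compound 3 (within the scatter), which amounts to no change beyond the scatter.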

Compound 3, a percentage reported as inhibition, at one concentration (the size of the read-out at that concentration, not a potency): 0%
Estimate against measurement, compound 3: 2 percentage points above, and the stated range covers the measured number.
By their numbers in this assay, from the lowest: compounds 2, 3 and 1 (each within the scatter of the next).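

Pyridin-3-yl brings a ring nitrogen and a hydrogen-bond acceptor to the amine nitrogen of the six-membered ring, and it has fewer heavy atoms than either earlier group, yet this assay gives no change at the digits printed from compound 2 to compound 3 (within the scatter) and a number 1 percentage points lower from compound 1 to compound 3 (within the scatter). For the compounds shown here, the earlier compounds both carried a substituted aromatic ring of carbon only, so this is the first sign that a hetero atom in that ring, without any chlorine or trifluoromethyl, also gives no step beyond the scatter. Nothing available explains why the numbers stay this close.

As far as these compounds go, whether any group at this position can give clear inhibition remains open, as all three numbers lie close to zero. A benzyl group, a short alkyl chain or a carboxylic acid on that nitrogen could test this, and so could a different group in place of the 4-chlorophenyl ketone.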